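Chloro for trifluoromethyl: expected growth inhibition of compound 4

The source may report more compounds than this note shows. Statements on the series, on what has been measured and on what is new or still open speak of the compounds shown alone.

Measured so far:
compound 1 `COC(=O)c1nc(C)n(-c2ccccc2)n1` – in a functional assay on Jurkat cells (Homo sapiens) for inhibition, read by MTT assay, with a stated time of 72 h (a lower number here means a stronger inhibitor of growth, a higher number a weaker inhibitor of growth), compound 1 gives > 100000 nM, a limit of the assay.
compound 2 `COC(=O)c1nc(C)n(-c2ccccc2C(F)(F)F)n1` – in this assay compound 2 gives > 100000 nM, also a limit.
compound 3 `COC(=O)c1nc(C)n(-c2ccc(C(F)(F)F)cc2)n1` – in this assay compound 3 gives 9100 nM.

Compound 3 holds the only number shown; the two other values sit at the limit of > 100000 nM in this assay, at which 2 of the 3 values shown sit. The step of an at least 10-fold lower number from compound 1 to compound 3 (1.04 log units; beyond the scatter) is large, whereas a step that the two limits leave unreadable from compound 1 to compound 2 cannot be sized. Compound 4 `COC(=O)c1nc(C)n(-c2ccc(Cl)cc2)n1` differs from compound 3 by chloro in place of trifluoromethyl on an aromatic carbon. Among the compounds with values here, no measured step exchanges these two groups; the one bearing step, an at least 10-fold lower number from compound 1 to compound 3 (1.04 log units; beyond the scatter), shows that the group being removed carried a large gain. A moderate rise in this assay is therefore expected, a 2.2-fold higher number from compound 3 to compound 4 (0.34 log units; beyond the scatter). Compound 4 is estimated at 20000 nM, range 6000 nM to 80000 nM.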

Compound 4, concentration for 50% growth inhibition: 65900 nM
Compound 4: middle estimate off by 3.3-fold (0.52 log units), on the low side; the range from low to high includes it.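

In this assay, the group on this aromatic carbon matters beyond merely being present: chloro in place of trifluoromethyl gives a 7.2-fold higher number from compound 3 to compound 4 (0.86 log units; beyond the scatter), so the gain seen with compound 3 does not carry over to chloro. Chloro in place of hydrogen gives an at least 1.5-fold lower number from compound 1 to compound 4 (0.18 log units; that floor lies within the scatter), so no gain from chloro is established. Compound 1 gives > 100000 nM, which is a limit of the assay.

From the compounds shown here alone, whether an amine or a nitrile on this carbon would retain the gain of trifluoromethyl remains open, as does the effect of a carboxylic acid in place of the methyl ester. The step from compound 1 to compound 2 cannot be read.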